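The source may hold more compounds than are shown below. What is called first, only, known or untested is meant among the compounds shown, and "the series" means these compounds.

Compound 1 (`O=C(Nc1ccc(Cl)cc1)N1CCC[C@H]1c1nc(-c2cccc(F)c2)no1`) returns only a limit (> 50000 nM) in an ADME assay on MCF-10A cells (Homo sapiens) for inhibition, with a stated time of 48 h; a higher number here means a weaker inhibitor, a lower number a stronger inhibitor. Compound 2 (`Cc1ccc(-c2noc([C@@H]3CCCN3C(=O)Nc3ccc(Cl)cc3)n2)cc1`) also returns only a limit (> 50000 nM) in this assay. Compound 3 (`O=C(Nc1ccc(Cl)cc1)N1CCC[C@H]1c1nc(-c2ccc(Cl)cc2)no1`) likewise stands at a limit (> 50000 nM) and has no number. Compound 4 (`O=C(Nc1ccc(Cl)cc1)N1CCC[C@H]1c1nc(-c2ccc(Br)cc2)no1`) carries bromo in place of chloro on an aromatic carbon, para to a large group (bromo in place of chloro on an aromatic carbon). Among the measured compounds shown here, the measured steps that bear on this change (a step that the two limits leave unreadable from compound 2 to compound 3) and (a step that the two limits leave unreadable from compound 1 to compound 3) offer no size to carry over, and the only guide is the limit of > 50000 nM in this assay, at which 3 of the 3 values shown sit, in this assay. In this assay the expected step (a number no higher from compound 3 to compound 4 (the limit leaves the size open)) is none beyond the scatter, with no direction favoured. Compound 4 is estimated at 50000 nM within an expected range of 20000 nM to 100000 nM for now.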

Compound 4, half-maximal inhibitory concentration: > 50000 nM
Compound 4: no number, only a limit; the forecaster's own chance of this, stated with the estimate: 85%; the middle value lies on the limit itself.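

In this assay compound 4 gives > 50000 nM, a limit and not a number, so its steps from compound 1, compound 2 and compound 3 cannot be read. The compounds shown leave open how strongly any of them inhibits in this assay: the limit of > 50000 nM in this assay, at which 4 of the 4 values shown sit.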